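Replacing 4-methylbenzyl with 4-methylphenyl on sulfur

The source may report more compounds than this note shows. Statements on the series, on what has been measured and on what is new or still open speak of the compounds shown alone.

For the measured compounds named here, in a functional assay on DU-145 cells (Homo sapiens) for inhibition, read by trypan blue exclusion, with a stated time of 96 h (on this read-out higher numbers stand for weaker inhibition of growth and lower numbers for stronger inhibition of growth), compound 1 `COc1ccccc1/C=C(/SCc1ccc(F)cc1)C(=O)c1ccc(Cl)cc1` gives 10000 nM and compound 2 `COc1ccccc1/C=C(/SCc1ccc(C)cc1)C(=O)c1ccc(Cl)cc1` gives 10000 nM, so compound 2 stands level with its only measured neighbour. Compound 3 `COc1ccccc1/C=C(/Sc1ccc(C)cc1)C(=O)c1ccc(Cl)cc1` carries 4-methylphenyl in place of 4-methylbenzyl on a sulfur. Going by the values given here, the single measured step, no change at the digits printed from compound 1 to compound 2 (within the scatter), is methyl in place of fluoro on an aromatic carbon, so it bears only indirectly, and no measured step tests this change at the sulfur. The expected result is no change at the digits printed from compound 2 to compound 3 (within the scatter), with no shift in either direction expected beyond the scatter. For compound 3 the estimated value in this assay is 10000 nM, with a range of 4000 nM to 25000 nM.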

Compound 3, concentration for 50% growth inhibition: 25000 nM
The estimate for compound 3 lay 2.5-fold (0.40 log units) below the measured number, within the range that was stated.
By their numbers in this assay, from the lowest: compounds 1 and 2 (each within the scatter of the next); then compound 3.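

In this assay, the group on the sulfur is the first place shown where a change moves the number: 4-methylphenyl in place of 4-methylbenzyl gives a 2.5-fold higher number from compound 2 to compound 3 (0.40 log units; beyond the scatter), a modest loss of growth inhibition. 4-Methylphenyl in place of 4-fluorobenzyl gives a 2.5-fold higher number from compound 1 to compound 3 (0.40 log units; beyond the scatter), so the shift appears from either benzyl compound. No measurement shown here explains this shift. Still open, going by these compounds, is how a longer chain, such as 2-phenylethyl, would read on the sulfur, and how an amine would read in place of the methyl of 4-methylphenyl.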